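A few compounds are considered here, and "the series" means these few. Any claim that something is new, unique, unknown or untested is made for them only; others in the source may bear on it.

Measured so far in a functional assay on HeLa cells (Homo sapiens) for antiproliferative activity, read by MTT assay, with a stated time of 72 h; on this read-out lower numbers stand for stronger inhibition and higher numbers for weaker inhibition:
Compound 1 `Cc1ccc2c(=O)c(CSC(=S)N(C(C)C)C(C)C)coc2c1` gives 1400 nM.
Compound 2 `O=c1c(CSC(=S)N2CCOCC2)coc2cc(Cl)ccc12` gives 2000 nM.
Compound 3 `CC(C)N(C(=S)SCc1coc2cc(Cl)ccc2c1=O)C(C)C` gives only a limit, > 25000 nM.

Within the data shown here, compound 2 and compound 1 are the only two with a number, and they lie within the scatter of each other, so neither can be called the stronger. Compound 4 `Cc1ccc2c(=O)c(CSC(=S)N3CCOCC3)coc2c1` is compound 2 with one change: methyl in place of chloro on an aromatic carbon. Among the measured compounds shown here, two measured steps touch on it. The step of an at least 17-fold higher number from compound 1 to compound 3 (1.25 log units; beyond the scatter) is the same swap run backwards, but with diisopropylamino rather than morpholin-4-yl on the thiocarbonyl carbon. The step of an at least 12-fold higher number from compound 2 to compound 3 (1.09 log units; beyond the scatter) changes only that amine and also reaches the limit. Both steps end at compound 3, which sits at the limit of > 25000 nM in this assay, at which 1 of the 3 values shown sits, so each size is a lower bound and the two changes cannot be pulled apart. Taken alone, the reversed swap points toward a lower number for compound 4, while the closeness of compound 1 and compound 2 points toward little change. The expected step of a 1.7-fold lower number from compound 2 to compound 4 (0.22 log units; within the scatter) is therefore modest. Compound 4 is estimated at 1200 nM, between 500 nM and 3000 nM.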

Compound 4, half-maximal inhibitory concentration: 6100 nM
For compound 4 the middle estimate is 5.1-fold (0.71 log units) below the measured one; measured number above the stated range.
By their numbers in this assay, from the lowest: compounds 1 and 2 (each within the scatter of the next); then compound 4. At a limit, above all of these: compound 3.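

In this assay, methyl in place of chloro on this aromatic carbon now has a step with a number at both ends, a 3.1-fold higher number from compound 2 to compound 4 (0.48 log units; beyond the scatter), and morpholin-4-yl in place of diisopropylamino on the thiocarbonyl carbon likewise gives a 4.4-fold higher number from compound 1 to compound 4 (0.64 log units; beyond the scatter). The two changes therefore do not simply add up, as chloro gives the higher number with diisopropylamino but the lower number with morpholin-4-yl: the same change on two cores in this assay, an at least 17-fold higher number (1.25 log units; beyond the scatter) from compound 1 to compound 3 and a 3.1-fold lower number (0.48 log units; beyond the scatter) from compound 4 to compound 2, at least 54-fold (1.73 log units) apart, beyond the scatter of two such steps. Seen from the amine, morpholin-4-yl gives the lower number with chloro but the higher number with methyl: the same change on two cores in this assay, an at least 12-fold higher number (1.09 log units; beyond the scatter) from compound 2 to compound 3 and a 4.4-fold lower number (0.64 log units; beyond the scatter) from compound 4 to compound 1, at least 54-fold (1.73 log units) apart, beyond the scatter of two such steps.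

Going by these compounds, it remains open whether this reversal extends to other groups on the aromatic carbon, such as fluoro, bromo or methoxy, or to other amines, such as piperidin-1-yl or dimethylamino. The compounds shown also do not explain why the two sites depend on each other.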